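This account rests on a few compounds, and the source may have more. Where it says the series, first, only, none or still open, it means among the compounds named here.

Compound 2, `OCCCNc1nnc(-c2ccc(F)c(F)c2Nc2ccc(I)cc2F)o1`, is the starting point for the step considered here. In a physicochemical assay for solubility, read by HPLC, in phosphate buffer, at pH 6.5 (a higher number here means a more soluble compound, a lower number a less soluble compound), compound 2 gives < 3 ug/mL, a limit of the assay rather than a measured number. Its closest measured relative is compound 1, `CCN(CC)CCCNc1nnc(-c2ccc(F)c(F)c2Nc2ccc(I)cc2F)o1`, which differs from it only by hydroxy in place of diethylamino on a saturated chain carbon, three bonds along the chain from a nitrogen on an aromatic ring. In this assay compound 1 gives < 3 ug/mL, again a limit and not a number. The step that the two limits leave unreadable from compound 1 to compound 2 is therefore of unknown size, because of the limit of < 3 ug/mL in this assay, at which 2 of the 2 values shown sit. Compound 3, `NCCNc1nnc(-c2ccc(F)c(F)c2Nc2ccc(I)cc2F)o1`, is the compound not yet measured; its difference from compound 2 is amino in place of hydroxymethyl on a saturated chain carbon, two bonds along the chain from a nitrogen on an aromatic ring. The measured step gives no readable size, so no direction can be drawn from it for compound 3. Given that the step from compound 2 is expected as a number no lower from compound 2 to compound 3 (the limit leaves the size open), compound 3 is estimated to give 3 ug/mL, within a range from 1 ug/mL to 15 ug/mL, and it is expected that this assay most likely again reports only a limit.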

Compound 3, solubility: < 3 ug/mL
Compound 3 gave a limit, no number; the forecaster's own chance of this, stated with the estimate: 60%; the middle value lies on the limit itself.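

In this assay compound 3 gives < 3 ug/mL, a limit of the assay and not a number. No step between compound 1, compound 2 and compound 3 can be read, because all of them stop at the same limit: the limit of < 3 ug/mL in this assay, at which 3 of the 3 values shown sit.

As far as these compounds go, how far apart these three compounds truly lie in solubility remains open.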